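Swapping a Ring-Bearing Amine for Piperidine on the Core

This account rests on a few compounds, and the source may have more. Where it says the series, first, only, none or still open, it means among the compounds named here.

Among the compounds with values here, compound 1 `Nc1nc(NCC2CCCCC2)c2c(n1)NCC(c1ccc(Cl)cc1)N2` is the weaker of the two compounds measured so far in an assay on isolated protein for inhibition of Nitric oxide synthase, inducible (Homo sapiens), with a stated time of 30 min; a higher number here means a weaker inhibitor, a lower number a stronger inhibitor: compound 1 gives 214000 nM, while compound 2 `CNCC1CNc2nc(N)nc(O)c2N1` gives 10600 nM, a gap beyond the usual scatter. Compound 3 `Nc1nc2c(c(N3CCCCC3)n1)NC(c1ccc(Cl)cc1)CN2` is built from compound 1 by one change: piperidin-1-yl in place of (cyclohexylmethyl)amino on an aromatic carbon. Within the data shown here, no measured pair shows the effect of this change, so the expectation rests on the weak showing of compound 1 alone. Compound 3 is expected to lie close to compound 1 in this assay, with a step of a 1.1-fold lower number from compound 1 to compound 3 (0.03 log units; within the scatter) no larger than the scatter, giving an estimate of 200000 nM within a range from 50000 nM to 800000 nM.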

Compound 3, half-maximal inhibitory concentration: 106000 nM
For compound 3 the middle estimate is 1.9-fold (0.28 log units) above the measured one, and the stated range covers the measured number.
By their numbers in this assay, from the lowest: compound 2; then compound 3; then compound 1.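

Putting piperidin-1-yl in place of (cyclohexylmethyl)amino on this aromatic carbon gives a 2.0-fold lower number from compound 1 to compound 3 (0.31 log units; beyond the scatter) in this assay, so this position does respond to a change of amine, though the step is modest. The entering group has 0 hydrogen-bond donors where the leaving group has 1, and it has fewer heavy atoms, but nothing here shows which of these differences matters, if either does. Going by these compounds, whether morpholine or dimethylamino at this position would lower the number further stays open.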